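A few compounds are considered here, and "the series" means these few. Any claim that something is new, unique, unknown or untested is made for them only; others in the source may bear on it.

Values in a functional assay with Homo sapiens as the target; on this read-out lower numbers stand for stronger inhibition and higher numbers for weaker inhibition:
- compound 1 `CC(C)[C@H](NC(=O)COc1cccc2ccccc12)C(=O)N[C@@H](CC(=O)O)C(=O)COc1ccccc1C(F)(F)F`: 17300 nM
- compound 2 `CC(C)[C@H](NC(=O)COc1cccc2ccccc12)C(=O)N[C@@H](CC(=O)O)C(=O)COc1cccc(C(F)(F)F)c1`: 16600 nM
- compound 3 `CC(C)[C@H](NC(=O)COc1cccc2ccccc12)C(=O)N[C@@H](CC(=O)O)C(=O)COc1ccc(C(F)(F)F)cc1`: 12300 nM

At 12300 nM, compound 3 cannot be separated from the other two compounds. The measured steps are a 1.4-fold lower number from compound 1 to compound 3 (0.15 log units; within the scatter) and a 1.3-fold lower number from compound 2 to compound 3 (0.13 log units; within the scatter), and both lie within the scatter. Compound 4 `CC(C)[C@H](NC(=O)COc1cccc2ccccc12)C(=O)N[C@@H](CC(=O)O)C(=O)COc1ccc(Oc2ccccc2)cc1` departs from compound 3 by a larger change: phenoxy in place of trifluoromethyl on an aromatic carbon. In words, phenoxy stands in place of trifluoromethyl on an aromatic carbon, para to a large group.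

Among the compounds with values here, no measured step makes this exchange, so the evidence is only indirect. The three measured compounds differ only in where the trifluoromethyl sits on the phenyl, and those steps, including a 1.0-fold lower number from compound 1 to compound 2 (0.02 log units; within the scatter), stay within the scatter. These data give no direction for the exchange, and the wide range reflects that gap. The estimated step is a 1.0-fold lower number from compound 3 to compound 4 (0.01 log units; within the scatter), so no change beyond the scatter is expected. For compound 4, the expected value is 12000 nM, with an estimated range from 5000 nM to 30000 nM.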

Compound 4, half-maximal inhibitory concentration: 19000 nM
For compound 4 the middle estimate is 1.6-fold (0.20 log units) below the measured one, and the stated range covers the measured number.
By their numbers in this assay, from the lowest: compounds 3, 2, 1 and 4 (each within the scatter of the next).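

In this assay, putting phenoxy in place of trifluoromethyl on an aromatic carbon, para to a large group, gives a 1.5-fold higher number from compound 3 to compound 4 (0.19 log units; within the scatter), so even this larger group, with its own six-membered aromatic ring, brings no change that can be told from the scatter. The earlier compounds shown here only moved trifluoromethyl around the phenyl, whereas this step replaces the group itself, going from 4 heavy atoms to 7, and the four compounds still stay within the scatter of one another's neighbours in the ranking. Nothing measured here offers an explanation for this result.

On these data alone, whether an amine or a longer chain at this position would move the number beyond the scatter remains open. As far as these compounds go, it is also open whether changes elsewhere on the shared core would do so.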